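A few compounds are considered here, and "the series" means these few. Any claim that something is new, unique, unknown or untested is made for them only; others in the source may bear on it.

Working notes on the series. Of the compounds shown here, three have been measured in an assay on HEK293 cells for antagonist activity at Toll-like receptor 9 (Homo sapiens), read by spectrophotometry; a lower number here means a stronger inhibitor, a higher number a weaker inhibitor. Compound 1 `Nc1nc(N2CCN(C3CCCC3)CC2)c2ncn(CCCN3CCCC3)c2n1` gives 120 nM. Compound 2 `CCN1CCN(CCCn2cnc3c(N4CCN(CC)CC4)ncnc32)CC1` gives 1190 nM. Compound 3 `CCN1CCN(c2nc(NCc3ccc(F)cc3)nc3c2ncn3CCCN2CCCC2)CC1` gives 40 nM, the lowest of the three numbers; the nearest number is that of compound 1, with a difference beyond the scatter, and the furthest is that of compound 2, also beyond the scatter. None of these pairs differ in only one place, so no single-point step can be read from them; compound 1 and compound 2 simply show that the compound carrying a cyclopentyl group on its ring nitrogen sits at the lower number of the two.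

The next compound, compound 4 `Fc1ccc(CNc2nc(N3CCN(C4CCCC4)CC3)c3ncn(CCCN4CCCC4)c3n2)cc1`, is compound 3 with one change: cyclopentyl in place of ethyl on an amine nitrogen in a ring. The expectation from compound 3 to compound 4 in this assay is a small step downward, a 1.6-fold lower number from compound 3 to compound 4 (0.20 log units; within the scatter), possibly not beyond the scatter, because compound 1 gives 120 nM while carrying the same cyclopentyl group. Compound 4 is therefore estimated at 25 nM, with a range from 8 nM to 80 nM.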

Compound 4, half-maximal inhibitory concentration in the Toll-like receptor 9 assay: 100 nM
The estimate for compound 4 lay 4.0-fold (0.60 log units) below the measured number; the whole stated range lies below it.
By their numbers in the Toll-like receptor 9 assay, from the lowest: compound 3; then compounds 4 and 1 (each within the scatter of the next); then compound 2.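

In the Toll-like receptor 9 assay, cyclopentyl in place of ethyl on an amine nitrogen in a ring gives a 2.5-fold higher number from compound 3 to compound 4 (0.40 log units; beyond the scatter), so this position responds to the change when the 4-fluorobenzyl group is present, and the ethyl compound holds the lower number. With cyclopentyl at that position, 4-fluorobenzyl in place of hydrogen on a nitrogen on an aromatic ring gives a 1.2-fold lower number from compound 1 to compound 4 (0.08 log units; within the scatter), so this pair shows no readable gain from the 4-fluorobenzyl group. In a physicochemical assay for solubility, with a stated time of 18 h, at pH 7.4 (a higher number here means a more soluble compound, a lower number a less soluble compound), compound 3 gives 218 ug/mL and compound 4 gives 28 ug/mL, so the change to cyclopentyl carries a solubility loss as well as the higher number in the Toll-like receptor 9 assay: the measured solubility of compound 3, 218 ug/mL, and of compound 4, 28 ug/mL, a 7.8-fold lower number (0.89 log units; beyond the scatter)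

The compounds shown leave open whether the response at this position follows the ring or the carbon count, a question that an isopropyl or a cyclopropyl group on the same nitrogen would address. Also open, as far as these compounds go, are the size of the 4-fluorobenzyl step with ethyl on the amine nitrogen, and whether a 2-hydroxyethyl group there would hold both read-outs.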